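A cyclohexyl group replaces a hydroxyethyl group

The compounds below may be only part of what the source reports. "The series", "measured", "known", "first", "only" and "open" are said of these compounds alone.

In an ADME assay on HepG2 cells (Homo sapiens) for cytotoxicity, read by CellTiter-Glo, with a stated time of 48 h (on this read-out lower numbers stand for higher toxicity in this test and higher numbers for lower toxicity in this test), compound 1 `CS(=O)(=O)c1ccc(-c2nc3ccc(Cl)cc3nc2-c2ccc(Cl)cc2)cc1` reads 2000 nM and compound 2 `CCCCNc1nc2ccc(OC)cc2nc1S(C)(=O)=O` reads 20000 nM while compound 3 `COc1ccc2nc(NCCO)c(S(C)(=O)=O)nc2c1` reads 39800 nM on the same scale. Compound 3 therefore sits within the scatter of compound 2 and well above compound 1. Compound 4 `COc1ccc2nc(NC3CCCCC3)c(S(C)(=O)=O)nc2c1` changes one group of compound 3: cyclohexyl in place of 2-hydroxyethyl on a nitrogen on an aromatic ring. For the measured compounds named here, the one measured step that bears on this change is a 2.0-fold higher number from compound 2 to compound 3 (0.30 log units; within the scatter) at the same nitrogen. No single change links compound 1 to compound 3. A small move toward a lower number is therefore expected, no larger than the scatter: a 2.0-fold lower number from compound 3 to compound 4 (0.30 log units; within the scatter) in this assay is the expected step. The estimate for compound 4 is 20000 nM (expected range 7000 nM to 45000 nM).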

Compound 4, half-maximal cytotoxic concentration: 12600 nM
Compound 4: middle estimate off by 1.6-fold (0.20 log units), on the high side; the measured number falls inside the stated range.
By their numbers in this assay, from the lowest: compound 1; then compounds 4, 2 and 3 (each within the scatter of the next, the first and the last beyond it).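

In this assay, for the compounds shown here, cyclohexyl in place of 2-hydroxyethyl on this nitrogen gives a 3.2-fold lower number from compound 3 to compound 4 (0.50 log units; beyond the scatter), the first step at this position that lies beyond the scatter. Cyclohexyl in place of butyl gives a 1.6-fold lower number from compound 2 to compound 4 (0.20 log units; within the scatter), so the ring and the open butyl chain cannot be told apart here. Nothing shown gives a reason for either step.

Still open, from the compounds shown here alone, is whether the loss of the hydroxy group or the arrival of the ring matters more, as this change does both at once. A cyclopentyl ring, or a longer chain ending in an amine, would test this further.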